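Amide variation in a series sitting at the assay limit

The source may report more compounds than this note shows. Statements on the series, on what has been measured and on what is new or still open speak of the compounds shown alone.

Measured so far:
Compound 1 `COC1CN(C(=O)/C=C/c2ccncc2-c2ccc3ccccc3c2)C1` — in a functional assay on KB cells (Homo sapiens) for inhibition, read by sulforhodamine B assay, with a stated time of 72 h (on this read-out lower numbers stand for stronger inhibition of growth and higher numbers for weaker inhibition of growth), compound 1 gives > 10000 nM, a limit of the assay.
Compound 2 `Cn1ccc2cc(-c3cnccc3/C=C/C(=O)O)ccc21` — in this assay compound 2 gives > 10000 nM, also a limit.
Compound 3 `CNC(=O)/C=C/c1ccncc1-c1ccc2c(cnn2C)c1` — in this assay compound 3 gives > 10000 nM, again a limit.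

Compound 1 therefore stands only at the limit of > 10000 nM in this assay, at which 3 of the 3 values shown sit, with no number of its own; every measured member of the series sits at that same limit. Within the data shown here, no pair of measured compounds differs in a single place, so no measured step is available.

Compound 4 `O=C(/C=C/c1ccncc1-c1ccc2ccccc2c1)NC1CC1` carries the change (cyclopropylamino in place of 3-methoxyazetidin-1-yl on a carbonyl carbon). With all three measured values at the limit, the step from compound 1 to compound 4 is expected to be a step that the limit leaves unreadable from compound 1 to compound 4, none beyond the scatter. Compound 4 is estimated at 15000 nM, expected range 5000 nM to 50000 nM, most likely reported as a limit.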

Compound 4, concentration for 50% growth inhibition: 6050 nM
Compound 4: the middle estimate sits 2.5-fold (0.39 log units) above what was measured; the range from low to high includes it.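

In this assay compound 4 is the first compound shown with a number and not a limit: the limit of > 10000 nM in this assay, at which 3 of the 4 values shown sit. Cyclopropylamino in place of 3-methoxyazetidin-1-yl on a carbonyl carbon gives an at least 1.6-fold lower number from compound 1 to compound 4 (0.21 log units; that floor lies within the scatter), so a change at this carbonyl carbon can bring the series into measurable range, although the floor of this step does not establish a difference beyond the scatter.

From the compounds shown here alone, the true size of the step stays open. Also open, going by these compounds, is whether cyclobutylamino or dimethylamino on the same carbonyl carbon keeps a number on the core of compound 4 or returns to the limit.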